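The compounds below may be only part of what the source reports. "The series", "measured", "known", "first", "only" and "open" are said of these compounds alone.

Working notes. In a toxicity assay on THP-1 cells (Homo sapiens) for inhibition (on this read-out lower numbers stand for higher toxicity in this test and higher numbers for lower toxicity in this test), compound 2 (`COc1ccc(-c2cnc(NC(=O)c3ccc(F)cc3)n2C)cc1`) gives >= 50000 nM, which is a limit and not a number. Compound 1 (`COc1ccc(-c2cnc(NC(=O)CCc3ccccc3)n2C)cc1`) gives > 100000 nM, also a limit. For the measured compounds named here, the one measured step is a step that the two limits leave unreadable from compound 1 to compound 2, so it offers no size to carry forward. Compound 3 (`COc1ccc(-c2cnc(NC(=O)c3ccccc3Br)n2C)cc1`) has 2-bromophenyl in place of 4-fluorophenyl on a carbonyl carbon. No step beyond the scatter is expected in this assay, and another limit is likely. Compound 3 is estimated at 60000 nM, within an expected range of 20000 nM to 150000 nM. The expected change is a step that the limit leaves unreadable from compound 2 to compound 3.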

Compound 3, half-maximal cytotoxic concentration: > 100000 nM
Compound 3 was reported as a limit; the forecaster's own chance of this, stated with the estimate: 70%; at least 1.6-fold (0.22 log units) between middle value and limit.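

For the compounds shown here, no step among compound 1, compound 2 and compound 3 can be read in this assay: all three values are limits. The compounds shown leave open whether any group on the carbonyl carbon gives a measurable half-maximal cytotoxic concentration in this assay.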